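Pyridin-2-yl in place of phenyl on the chlorophenyl pyridines

This account rests on a few compounds, and the source may have more. Where it says the series, first, only, none or still open, it means among the compounds named here.

Measured so far:
compound 1, `Oc1ccc(-c2cc(-c3ccccn3)nc(-c3ccccc3Cl)c2)cc1`: 5.2%
compound 2, `Oc1ccc(-c2cc(-c3ccccc3)nc(-c3ccccc3Cl)c2)cc1`: 13.6%
compound 3, `Oc1ccc(-c2cc(-c3ccccc3)nc(-c3ccc(Cl)cc3)c2)cc1`: 68%

All three were run in an assay on isolated protein for inhibition of DNA topoisomerase 1 (Homo sapiens), with a stated time of 30 min, tested at 100 uM; on this read-out higher numbers stand for a stronger effect at the one concentration tested and lower numbers for a weaker effect. Compound 3 stands highest of the three; its steps to compound 2 and to compound 1 are both beyond the scatter. The cores of compound 2 and compound 3 differ by 4-chlorophenyl in place of 2-chlorophenyl on an aromatic carbon, and that single rearrangement carries the large step of a number 54.4 percentage points higher from compound 2 to compound 3 (beyond the scatter).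

The change from compound 2 to compound 1 is pyridin-2-yl in place of phenyl on an aromatic carbon; it gave a number 8.4 percentage points lower from compound 2 to compound 1 (within the scatter), a step within the scatter.

Compound 4, `Oc1ccc(-c2cc(-c3ccc(Cl)cc3)nc(-c3ccccn3)c2)cc1`, remains to be measured. It arises from compound 3 by pyridin-2-yl in place of phenyl on an aromatic carbon. Among the measured compounds shown here, this is the same kind of change as the one from compound 2 to compound 1, but not the same: the place is now meta to a 4-chlorophenyl group rather than meta to a 2-chlorophenyl group, with the 4-hydroxyphenyl group unchanged.

The step from compound 3 to compound 4 in this assay is expected to be about a number 10 percentage points lower from compound 3 to compound 4 (within the scatter), near the earlier one, because a number 8.4 percentage points lower from compound 2 to compound 1 (within the scatter) was small. Compound 4 is therefore estimated at 58%, with 32% to 78% as the likely range.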

Compound 4, a percentage reported as inhibition, at one concentration (the size of the read-out at that concentration, not a potency): 12.7%
The estimate for compound 4 lay 45.3 percentage points above the measured number, and the stated range ends above it.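

In this assay, pyridin-2-yl in place of phenyl gives a number 55.3 percentage points lower from compound 3 to compound 4 (beyond the scatter) with the 4-chlorophenyl group present, so the small step seen with the 2-chlorophenyl group does not carry over: the same change on two cores in this assay, a number 8.4 percentage points lower (within the scatter) from compound 2 to compound 1 and a number 55.3 percentage points lower (beyond the scatter) from compound 3 to compound 4, 46.9 percentage points apart, beyond the scatter of two such steps. Read the other way, 4-chlorophenyl in place of 2-chlorophenyl gives a number 7.5 percentage points higher from compound 1 to compound 4 (within the scatter), so the large gain seen with phenyl does not recur with pyridin-2-yl: the same change on two cores in this assay, a number 54.4 percentage points higher (beyond the scatter) from compound 2 to compound 3 and a number 7.5 percentage points higher (within the scatter) from compound 1 to compound 4, 46.9 percentage points apart, beyond the scatter of two such steps. The two changes therefore do not act independently across these four compounds, and the high read-out occurs only where phenyl and 4-chlorophenyl stand together, in compound 3, but this single set of four compounds shows neither why the steps differ nor whether the same holds on any other core.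

Open, from the compounds shown here alone, is whether any ring nitrogen in that place gives the same drop, as pyridin-3-yl or pyridin-4-yl on the core of compound 3 would show. Also open, going by these compounds, is how a 3-chlorophenyl group, or a 4-methoxyphenyl group in place of 4-hydroxyphenyl, would read on that core.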